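Substituent swap at the limit of the assay

This account rests on a few compounds, and the source may have more. Where it says the series, first, only, none or still open, it means among the compounds named here.

Measured in a functional assay on NIH3T3 cells (Mus musculus) for antiproliferative activity, with a stated time of 72 h; a higher number here means a weaker inhibitor, a lower number a stronger inhibitor:
- compound 1 `O=[N+]([O-])c1cccc(CNc2cc(C(F)(F)F)cc3ncc(N4CCN(S(=O)(=O)C5CC5)CC4)cc23)c1` gives >= 50000 nM (a limit)
- compound 2 `CS(=O)(=O)N1CCN(c2cnc3cc(C(F)(F)F)cc(NCc4cccc([N+](=O)[O-])c4)c3c2)CC1` gives >= 50000 nM (a limit)

Compound 2 sits at the limit >= 50000 nM and has no number. The change to compound 3 `CCOC(=O)CN1CCN(c2cnc3cc(C(F)(F)F)cc(NCc4cccc([N+](=O)[O-])c4)c3c2)CC1` is (ethoxycarbonyl)methyl in place of methylsulfonyl on an amine nitrogen in a ring and leaves the rest of the structure as it is. Going by the values given here, the only measured step is a step that the two limits leave unreadable from compound 1 to compound 2 and gives no size to carry over. the limit of >= 50000 nM in this assay, at which 2 of the 2 values shown sit, is all the evidence on this series. No step beyond the scatter is therefore expected in this assay and no direction is favoured. The expected outcome is a number no higher from compound 2 to compound 3 (the limit leaves the size open) on this reading. Compound 3 is expected near 50000 nM with an estimated range of 20000 nM to 100000 nM. A limit in place of a number is also to be expected for compound 3.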

Compound 3, half-maximal inhibitory concentration: >= 50000 nM
Compound 3: only a limit was reported; the forecaster's own chance of this, stated with the estimate: 80%; the middle value sits exactly at the limit.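

Compound 3, like compound 1 and compound 2, is reported only as a limit in this assay, so no new step can be read among the three. The compounds shown leave open whether any group on this ring amine nitrogen gives a measurable value.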